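Dropping one chloro from a dichlorophenyl amide

A few compounds are considered here, and "the series" means these few. Any claim that something is new, unique, unknown or untested is made for them only; others in the source may bear on it.

Measured compounds:
compound 1, `O=C(CSc1nnc(-c2ccncc2)s1)Nc1ccc(Cl)cc1`: > 50000 nM
compound 2, `O=C(CSc1nnc(-c2ccncc2)s1)Nc1c(Cl)cccc1Cl`: "not determined" (no result reported)

In an ADME assay on HepG2 cells (Homo sapiens) for cytotoxicity, with a stated time of 3 days (a lower number here means that less compound is tolerated, a higher number that more compound is tolerated), compound 1 reaches only the assay limit of > 50000 nM. In this assay compound 2 stands as "not determined" (no result reported), so no number is known for it. Compound 3, `O=C(CSc1nnc(-c2ccncc2)s1)Nc1ccccc1Cl`, is not yet measured. It differs from compound 2 by hydrogen in place of chloro on an aromatic carbon. For the measured compounds named here, with the one reading at the limit of > 50000 nM in this assay, at which 1 of the 2 values shown sits, no step beyond the scatter is expected. Compound 3 is estimated at 50000 nM, with a range from 20000 nM to 100000 nM, most likely again reported as a limit.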

Compound 3, half-maximal cytotoxic concentration: > 50000 nM
Compound 3 was reported as a limit; the forecaster's own chance of this, stated with the estimate: 75%; the middle value sits exactly at the limit.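

For the compounds shown here, compound 1 and compound 3 are both reported only as limits in this assay, so no step between them can be read. Going by these compounds, the true values of both compounds, and any value for compound 2, remain open.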